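The source may report more compounds than this note shows. Statements on the series, on what has been measured and on what is new or still open speak of the compounds shown alone.

Measured compounds:
compound 1 `Cc1ccc(-c2cs/c(=N/NC(=O)CSc3nnnn3-c3ccccc3)n2-c2ccccc2)cc1` gives 22.2%
compound 2 `Cn1nnnc1SCC(=O)N/N=c1/scc(-c2ccc(C#N)cc2)n1-c1ccccc1` gives 28.6%
compound 3 `O=C(CSc1nnnn1-c1ccccc1)N/N=c1/scc(-c2ccccc2)n1-c1ccccc1` gives 22.6%

All three were run in a functional assay on C6 cells (Rattus norvegicus) for cytotoxicity, read by MTT assay, with a stated time of 24 h, tested at 200 ug/mL; on this read-out higher numbers stand for a weaker effect at the one concentration tested and lower numbers for a stronger effect. Compound 3 stands second highest of the three numbers; its nearest neighbour is compound 1, lower by a margin within the scatter, and its furthest is compound 2, higher by a margin that is also within the scatter. Among the measured compounds shown here, the one single-point step measured so far, a number 0.4 percentage points higher from compound 1 to compound 3 (within the scatter), is within the scatter.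

Compound 4 `N#Cc1ccc(-c2cs/c(=N/NC(=O)CSc3nnnn3-c3ccccc3)n2-c2ccccc2)cc1` is the next compound to be measured. It differs from compound 3 by cyano in place of hydrogen on an aromatic carbon. For the measured compounds named here, no measured step changes this position in the same way. Compound 2 carries the same cyano group on its aryl ring but differs from compound 3 elsewhere as well, so only its own value can be set beside that of compound 3, and the two lie within the scatter of each other. Going by the values given here, the one change measured on this ring, from compound 1 to compound 3, gave no step beyond the scatter. On that basis no step beyond the scatter is expected from compound 3 to compound 4 either; the expected step is a number 2.4 percentage points higher from compound 3 to compound 4 (within the scatter). Compound 4 is therefore estimated at 25%, in a range from 15% to 36%.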

Compound 4, a percentage reported as activity, at one concentration (the size of the read-out at that concentration, not a potency): 54%
For compound 4 the middle estimate is 29 percentage points below the measured one; the measured number lies above the stated range.
By their numbers in this assay, from the lowest: compounds 1, 3 and 2 (each within the scatter of the next); then compound 4.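

In this assay, this ring position now shows a step beyond the scatter, where the exchange of methyl for hydrogen on the same carbon had not: with cyano in place of hydrogen the result is a number 31.4 percentage points higher from compound 3 to compound 4 (beyond the scatter), and with cyano in place of methyl it is a number 31.8 percentage points higher from compound 1 to compound 4 (beyond the scatter), both towards a weaker effect at the one concentration tested. The phenyl to 4-cyanophenyl change therefore separates from the other changes measured at this carbon. With cyano held on the ring, the group on the aromatic nitrogen also counts, since phenyl in place of methyl there gives a number 25.4 percentage points higher from compound 2 to compound 4 (beyond the scatter).

Nothing measured in this series bears on why these steps arise. Going by these compounds, whether a step of this size is particular to cyano stays open, as an amine or a carboxylic acid at this position would show.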